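Extending the aromatic amine of compound 2 with a glycinamide chain

This account rests on a few compounds, and the source may have more. Where it says the series, first, only, none or still open, it means among the compounds named here.

Measured so far:
compound 1, `CN1Cc2c(N)cccc2C(c2ccc(F)cc2)C1`, 7.5 mg/kg
compound 2, `Cc1ccc(C2CN(C)Cc3c(N)cccc32)cc1`, about 22 mg/kg
compound 3, `CC(C)c1ccc(C2CN(C)Cc3c(N)cccc32)cc1`, about 65 mg/kg

In a functional assay on the whole organism for inhibition of sodium-dependent dopamine transporter (Mus musculus) (on this read-out higher numbers stand for an effect only at larger amounts of compound and lower numbers for an effect already at smaller amounts), compound 2 sits in the middle of the three numbers: a 2.9-fold higher number from compound 1 to compound 2 (0.47 log units; beyond the scatter), while a 3.0-fold higher number from compound 2 to compound 3 (0.47 log units; beyond the scatter). All three measured steps alter only the substituent on the pendant aromatic ring. The unmeasured compound 4, `CCCCNCC(=O)Nc1cccc2c1CN(C)CC2c1ccc(C)cc1`, differs from compound 2 elsewhere: ((butylamino)methyl)carbonyl in place of hydrogen on a nitrogen on an aromatic ring. Among the measured compounds shown here, no measured step touches this amine nitrogen, so none bears directly on the change, and the expectation rests on compound 2 alone. A fairly small move is expected, a 1.4-fold higher number from compound 2 to compound 4 (0.13 log units; within the scatter), with wide uncertainty. Compound 4 is therefore estimated at 30 mg/kg in this assay, within a range from 8 mg/kg to 120 mg/kg.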

Compound 4, dose for half-maximal effect: 14 mg/kg
For compound 4 the middle estimate is 2.1-fold (0.33 log units) above the measured one, within the range that was stated.
By their numbers in this assay, from the lowest: compounds 1, 4 and 2 (each within the scatter of the next, the first and the last beyond it); then compound 3.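

The earlier compounds shown here changed only the substituent on the pendant aromatic ring, whereas this change puts ((butylamino)methyl)carbonyl on the amine nitrogen. In this assay the result is a 1.6-fold lower number from compound 2 to compound 4 (0.20 log units; within the scatter) and so no real difference. This nitrogen can therefore carry a chain of this size while the number stays in the range of compound 2. No measurement at hand explains why so large an addition leaves the number so little changed.

Still open, from the compounds shown here alone, is whether an acetyl group, a longer chain or a carboxylic acid at the end of the chain would keep the number in that range. Also open, going by these compounds, is whether the same chain would behave alike on compound 1 or compound 3.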